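The compounds below may be only part of what the source reports. "The series", "measured", "known", "first", "only" and "open" are said of these compounds alone.

Measured so far in an ADME assay on MT4 cells (Homo sapiens) for cytotoxicity, read by MTT assay, with a stated time of 96 h; a lower number here means that less compound is tolerated, a higher number that more compound is tolerated:
compound 1 `Cn1c(-c2ccc(NC(=O)CN3CCCC3)cc2)nc2cc(C(F)(F)F)ccc21` — 16000 nM
compound 2 `CCC(=O)Nc1ccc(-c2nc3cc(C(F)(F)F)ccc3n2C)cc1` — 8000 nM

Compound 2 and compound 1 stand within the scatter of each other, since a 2.0-fold lower number from compound 1 to compound 2 (0.30 log units; within the scatter) is within the scatter. Compound 3 `Cn1c(-c2ccc(NC(=O)CN3CCCCC3)cc2)nc2cc(C(F)(F)F)ccc21` differs from compound 2 by piperidin-1-yl in place of methyl on a saturated chain carbon bound to a carbonyl carbon. Among the compounds with values here, the one measured step that bears on this change is a 2.0-fold lower number from compound 1 to compound 2 (0.30 log units; within the scatter), which runs the opposite way and stays within the scatter. Compound 3 is therefore expected to shift back toward compound 1 by no more than the scatter, a 1.8-fold higher number from compound 2 to compound 3 (0.24 log units; within the scatter). In this assay compound 3 is estimated at 14000 nM, with a range from 6000 nM to 35000 nM.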

Compound 3, half-maximal cytotoxic concentration: 9000 nM
Compound 3: the middle estimate sits 1.6-fold (0.19 log units) above what was measured; measured number inside the range.
By their numbers in this assay, from the lowest: compounds 2, 3 and 1 (each within the scatter of the next).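

In this assay, piperidin-1-yl in place of methyl on a saturated chain carbon bound to a carbonyl carbon gives a step within the scatter (a 1.1-fold higher number from compound 2 to compound 3 (0.05 log units; within the scatter)), and piperidin-1-yl in place of pyrrolidin-1-yl does the same (a 1.8-fold lower number from compound 1 to compound 3 (0.25 log units; within the scatter)). Adding a six-membered non-aromatic ring at this position therefore leaves the reading indistinguishable from those of both compound 1 and compound 2. No measurement is available that would explain this result. The compounds shown leave open whether a carboxylic acid, a primary amine or a longer chain at this place would take the number beyond the scatter.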